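The compounds below may be only part of what the source reports. "The series", "measured", "known", "first", "only" and "open" are said of these compounds alone.

In a functional assay on LOX IMVI cells (Homo sapiens) for cytotoxicity, read by MTT assay, with a stated time of 24 h (on this read-out higher numbers stand for weaker inhibition and lower numbers for stronger inhibition), two compounds with the same core have been measured so far. Compound 1 `COc1cc(-c2nc(-c3ccccc3)[nH]c2-c2ccnc(NCCCNS(=O)(=O)c3ccc(F)cc3)n2)ccc1F`, with a 4-fluorophenyl on the sulfonyl sulfur, gives 3960 nM. Compound 2 `COc1cc(-c2nc(-c3ccccc3)[nH]c2-c2ccnc(NCCCNS(=O)(=O)c3cccc(F)c3)n2)ccc1F`, with a 3-fluorophenyl in that place, gives 900 nM, the lower of the two numbers and so the stronger inhibition. The next compound, compound 3 `COc1ccc(S(=O)(=O)NCCCNc2nccc(-c3[nH]c(-c4ccccc4)nc3-c3ccc(F)c(OC)c3)n2)cc1`, is changed at that same place: 4-methoxyphenyl in place of 3-fluorophenyl on a sulfonyl sulfur. In words, it has 4-methoxyphenyl in place of 3-fluorophenyl on a sulfonyl sulfur.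

Going by the values given here, only one measured step bears on this change, a 4.4-fold lower number from compound 1 to compound 2 (0.64 log units; beyond the scatter), a modest step but one beyond the usual scatter. It shows that the number responds to the group at this place. That step swapped one fluorophenyl for another, however, and no methoxy-bearing group has been measured, so the guidance is thin. Compound 3 shares the 4- naming of its group with compound 1, which reads 3960 nM, so a move back toward that number seems the likelier outcome. The expected change is a modest rise, a 2.4-fold higher number from compound 2 to compound 3 (0.39 log units; beyond the scatter). For compound 3 the estimated value is 2200 nM, with an expected range from 700 nM to 6500 nM.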

Compound 3, half-maximal inhibitory concentration: 6130 nM
For compound 3 the middle estimate is 2.8-fold (0.45 log units) below the measured one; the range from low to high includes it.
By their numbers in this assay, from the lowest: compound 2; then compounds 1 and 3 (each within the scatter of the next).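

Going by these compounds alone, the change from the 3-fluorophenyl to the 4-methoxyphenyl gives a 6.8-fold higher number from compound 2 to compound 3 (0.83 log units; beyond the scatter), so the first methoxy-bearing group at this place on the sulfonyl sulfur does not keep the low number, and compound 2 remains the strongest inhibitor of the three. Exchanging methoxy for fluoro among the two groups named with a 4 gives a 1.5-fold higher number from compound 1 to compound 3 (0.19 log units; within the scatter), which lies within the scatter, so the printed numbers do not separate the 4-fluorophenyl from the 4-methoxyphenyl. Across these three compounds, then, the two groups named with a 4 read alike and only the 3-fluorophenyl stands apart, although no supporting data explain why the numbers fall this way.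

These compounds leave open whether the lower number of compound 2 goes with the 3 in its group's name or needs the fluoro itself, since a fluoro group is the only one seen with that name. A 3-methoxyphenyl on the same sulfonyl sulfur would separate those two readings, while a plain phenyl would show how the number stands with neither fluoro nor methoxy on that ring.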